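The source may report more compounds than this note shows. Statements on the series, on what has been measured and on what is new or still open speak of the compounds shown alone.

Measured in a functional assay on A549 cells (Homo sapiens), read by MTT assay, with a stated time of 72 h (a lower number here means a stronger inhibitor, a higher number a weaker inhibitor), and all reported as limits:
- compound 1 `Cc1nc(N)c2c(-c3cccs3)cn([C@@H]3O[C@H](CO)[C@@H](O)[C@H]3O)c2n1` gives > 20000 nM as a limit
- compound 2 `Cc1nc(N)c2c(-c3ccccc3)cn([C@@H]3O[C@H](CO)[C@@H](O)[C@H]3O)c2n1` gives > 20000 nM as a limit
- compound 3 `COc1nc(N)nc2c1c(-c1ccoc1)cn2[C@@H]1O[C@H](CO)[C@@H](O)[C@H]1O` gives > 20000 nM as a limit

Compound 3 thus has a limit and not a number. The series rests on the limit of > 20000 nM in this assay, at which 3 of the 3 values shown sit, and offers no number to step from. Compound 4 `C#Cc1cn([C@@H]2O[C@H](CO)[C@@H](O)[C@H]2O)c2nc(N)nc(OC)c12` has ethynyl in place of furan-3-yl on an aromatic carbon, counted as ethynyl in place of furan-3-yl on an aromatic carbon in full. Among the measured compounds shown here, the one measured step on such a carbon is a step that the two limits leave unreadable from compound 1 to compound 2 and it has no readable size. For the measured compounds named here, no measured compound carries ethynyl, so a gain stays possible, but no step beyond the scatter in this assay is expected. The expected step is a number no higher from compound 3 to compound 4 (the limit leaves the size open) as estimated here. For compound 4 the estimate is 20000 nM with an expected range from 2000 nM to 20000 nM and another limit as the likeliest report.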

Compound 4, half-maximal inhibitory concentration: > 100000 nM
Compound 4: only a limit was reported; the forecaster's own chance of this, stated with the estimate: 70%; middle value at least 5.0-fold (0.69 log units) away from the limit.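

Compound 3 and compound 4 are both reported only as limits in this assay, so the step between them cannot be read. The compounds shown leave open how strongly, if at all, any of them inhibits.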